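This account rests on a few compounds, and the source may have more. Where it says the series, first, only, none or still open, it means among the compounds named here.

Measured so far:
- compound 1 `OC[C@H](NC[C@H]1NC[C@H](O)[C@@H]1O)c1ccc(-c2ccccc2)cc1`: compound 1 gives > 200000 nM in a functional assay on MDA-MB-231 cells (Homo sapiens) for cytotoxicity, read by colorimetric assay, with a stated time of 72 h (a lower number here means a stronger inhibitor, a higher number a weaker inhibitor), a limit of the assay.
- compound 2 `OC[C@H](NC[C@H]1NC[C@H](O)[C@@H]1O)c1ccc(-c2ccsc2)cc1`: compound 2 is reported as "not active" (no number reported) in this assay.
- compound 3 `C=CCOc1ccc([C@H](CO)NC[C@H]2NC[C@H](O)[C@@H]2O)cc1`: compound 3 gives > 200000 nM in this assay, again a limit.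

Compound 3 therefore stands at the edge of what this assay can read, and the step that the two limits leave unreadable from compound 1 to compound 3 cannot be sized, since both ends sit at the limit of > 200000 nM in this assay, at which 2 of the 3 values shown sit. Compound 4 `OC[C@H](NC[C@H]1NC[C@H](O)[C@@H]1O)c1ccc(OCc2ccccc2)cc1` differs from compound 3 in that (phenyl in place of vinyl on a saturated chain carbon bound to an oxygen on an aromatic ring). No measured step offers a readable size for comparison, and every compound shown is inactive or at the limit. Within the data shown here, the expectation is that compound 4 stays beyond the limit as well, with no step expected beyond the scatter, a step that the limit leaves unreadable from compound 3 to compound 4. Compound 4 is thus estimated at 300000 nM, ranging from 100000 nM to 1000000 nM.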

Compound 4, half-maximal inhibitory concentration: "not active" (no number reported)
The entry for compound 4 holds no number; the estimate stays without a comparison.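

Compound 4 is reported as not active, with no number, so no step can be read from compound 3 to compound 4. The compounds shown leave open which change to the shared core, if any, would give a measurable value in this assay.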